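A Nitrile Replaces the Methyl on the Amide Ring

The source may hold more compounds than are shown below. What is called first, only, known or untested is meant among the compounds shown, and "the series" means these compounds.

Compound 2 `Cc1cccc(C(=O)Nc2ccc3[nH]cc(C4CCN(C)CC4)c3n2)c1` and compound 1 `CN1CCC(c2c[nH]c3ccc(NC(=O)c4cccc(F)c4)nc23)CC1` share one core and differ only in the group carried on the amide carbonyl. In an assay for binding affinity to 5-hydroxytryptamine receptor 1B (Homo sapiens), read by radioligand binding (a lower number here means a stronger inhibitor, a higher number a weaker inhibitor), compound 1 gives 1600 nM, and in this assay compound 2 gives 1200 nM. Within the data shown here, the only measured step, a 1.3-fold lower number from compound 1 to compound 2 (0.12 log units; within the scatter), lies within the scatter, so compound 2 holds the lower of the two numbers without being separated from compound 1 beyond the usual variation.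

Compound 3 `CN1CCC(c2c[nH]c3ccc(NC(=O)c4ccc(C#N)cc4)nc23)CC1` has not yet been measured. It differs from compound 2 by 4-cyanophenyl in place of 3-methylphenyl on a carbonyl carbon. Among the measured compounds shown here, no measured step exchanges a methyl group or a fluoro for a nitrile, so the only guide is a 1.3-fold lower number from compound 1 to compound 2 (0.12 log units; within the scatter), which showed that swapping one small group on this ring left the number essentially unchanged. From the compounds shown here alone, the change to a 4-cyanophenyl is untested here, and nothing in the two measured values argues for a step in either direction. Compound 3 is therefore expected to give 1500 nM in this assay, with a range of 500 nM to 4500 nM, an expected step of a 1.3-fold higher number from compound 2 to compound 3 (0.10 log units; within the scatter) that stays within the scatter.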

Compound 3, inhibition constant: 310 nM
For compound 3 the middle estimate is 4.8-fold (0.68 log units) above the measured one; the whole stated range lies above it.
By their numbers in this assay, from the lowest: compound 3; then compounds 2 and 1 (each within the scatter of the next).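

In this assay, the group on the carbonyl carbon proves able to move the number, which the earlier pair did not show: a 1.3-fold lower number from compound 1 to compound 2 (0.12 log units; within the scatter), whereas the new compound gives a 3.9-fold lower number from compound 2 to compound 3 (0.59 log units; beyond the scatter) and a 5.2-fold lower number from compound 1 to compound 3 (0.71 log units; beyond the scatter). Among these compounds, compound 3 therefore stands apart from both earlier compounds, and its step is the first at this position to lie beyond the scatter, though the size of that step remains modest. The entering 4-cyanophenyl brings a triple bond and a hydrogen-bond acceptor that neither 3-methylphenyl nor 3-fluorophenyl carries, but no evidence here connects either feature to the lower number.

The names 3-methylphenyl, 3-fluorophenyl and 4-cyanophenyl differ both in the group on the ring and in where it sits, so the compounds shown cannot say whether the nitrile itself or its placement goes with the lower number. They also leave open how other groups would behave in place of the nitrile, such as a carboxylic acid, an amine or a longer chain ending in a nitrile.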